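Removal of the trifluoromethyl group from compound 1

The source may hold more compounds than are shown below. What is called first, only, known or untested is meant among the compounds shown, and "the series" means these compounds.

Of the compounds shown here, three have numbers so far. In an assay on isolated protein for inhibition of Polyunsaturated fatty acid 5-lipoxygenase (Homo sapiens), with stated times of 15 min and 10 min (a higher number here means a weaker inhibitor, a lower number a stronger inhibitor), compound 1 `FC(F)(F)c1ccc(Nc2nc(-c3ccc(Cl)cc3)cs2)cc1` gives 5900 nM, the highest of the three numbers. Compound 3 `Oc1ccc(-c2csc(Nc3ccc(Cl)cc3)n2)cc1` gives 3100 nM in this assay, a number within the scatter of that of compound 1. Compound 2 `Oc1ccc(Nc2nc(-c3ccc(Cl)c(Cl)c3)cs2)cc1` gives 900 nM in this assay, a number beyond the scatter from that of compound 1, so compound 1 stands at the weak end of what has been measured.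

Compound 4 `Clc1ccc(-c2csc(Nc3ccccc3)n2)cc1` has not yet been measured in this assay. It differs from compound 1 in one place: hydrogen in place of trifluoromethyl on an aromatic carbon. Among the measured compounds shown here, no pair among the measured compounds shows this change alone, so the size of the step cannot be read from the data. The expectation is a step of modest size, not clearly beyond the scatter in either direction, with a slight lean toward a lower number, a 1.5-fold lower number from compound 1 to compound 4 (0.17 log units; within the scatter), since the measured compounds without this group sit at or below compound 1 in this assay. Compound 4 is therefore estimated at 4000 nM in this assay, with a range from 1000 nM to 16000 nM.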

Compound 4, half-maximal inhibitory concentration: 5600 nM
For compound 4 the middle estimate is 1.4-fold (0.15 log units) below the measured one; the range from low to high includes it.
By their numbers in this assay, from the lowest: compound 2; then compounds 3, 4 and 1 (each within the scatter of the next).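

In this assay, among the compounds shown here, hydrogen in place of trifluoromethyl on an aromatic carbon gives a 1.1-fold lower number from compound 1 to compound 4 (0.02 log units; within the scatter), the first step that isolates a change in one place. At this place, para to a large group, the values of compound 1 and compound 4 therefore cannot be told apart, and the trifluoromethyl group is not needed to hold the number of compound 1 in this assay. Nothing on hand bears on why the two compounds cannot be told apart.

From the compounds shown here alone, whether an amine, a carboxylic acid or a methoxy group at this place would move the number beyond the scatter from that of compound 4 remains open. Going by these compounds, a single pair carries this change, so it also remains open whether hydrogen in place of trifluoromethyl gives a step of the same size when the other parts of the core of compound 1 differ.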